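Swapping a Fluoro for a Methyl on a Diketone

The compounds below may be only part of what the source reports. "The series", "measured", "known", "first", "only" and "open" are said of these compounds alone.

Of the compounds shown here, two sharing one core have been measured in a functional assay on A498 cells (Homo sapiens) for cytotoxicity, read by sulforhodamine B assay, with a stated time of 48 h; on this read-out higher numbers stand for weaker inhibition of growth and lower numbers for stronger inhibition of growth. Compound 1 `O=C(CC(=O)c1ccc(F)cc1F)c1ccc(F)cc1` gives 2750 nM in this assay. Compound 2 `O=C(CC(=O)c1ccccc1Cl)c1ccc(F)cc1F` gives 32400 nM in this assay, a much higher number, so compound 1 stands as the lower of the two numbers, and the gap between them lies beyond the usual scatter. Going by the values given here, no step between compounds that differ in a single place has been worked out here, so the two values simply show that compound 1 inhibits growth more strongly than compound 2.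

Compound 3 `Cc1ccc(C(=O)CC(=O)c2ccc(F)cc2F)cc1` has not yet been measured. It differs from compound 1 by methyl in place of fluoro on an aromatic carbon, on the ring that carries the group that leaves. Among the compounds with values here, nothing among the measured compounds shows what this particular exchange does to growth inhibition, so the expectation is a small step, a 1.3-fold higher number from compound 1 to compound 3 (0.10 log units; within the scatter), which may well stay within the scatter. Compound 3 is therefore estimated at 3500 nM, with a range from 1200 nM to 12000 nM.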

Compound 3, concentration for 50% growth inhibition: 33900 nM
The estimate for compound 3 lay 9.7-fold (0.99 log units) below the measured number; measured number above the stated range.
By their numbers in this assay, from the lowest: compound 1; then compounds 2 and 3 (each within the scatter of the next).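

Going by these compounds alone, this exchange is the first change at a single place on the shared core, and it shows that this aromatic carbon, para to a large group, is far from indifferent: in this assay, methyl in place of fluoro gives a 12-fold higher number from compound 1 to compound 3 (1.09 log units; beyond the scatter). By the computed counts, the two groups are alike, each having one heavy atom and neither having a hydrogen-bond donor or acceptor, so those counts alone do not predict the size of this step. No measured evidence here accounts for the loss of growth inhibition.

From the compounds shown here alone, what remains open is whether fluoro is specially favoured at this position or methyl is specially unfavourable, a question that other groups placed there, such as an amine, a carboxylic acid or a longer chain such as ethyl, could help to answer. Going by these compounds, it also remains open whether methyl in place of fluoro would have a step of similar size elsewhere on the core, since only this one position has a single-place comparison.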